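Compound 2 loses one acyl group: expected step

A few compounds are considered here, and "the series" means these few. Any claim that something is new, unique, unknown or untested is made for them only; others in the source may bear on it.

In a functional assay on Hs 683 cells (Homo sapiens) for inhibition, read by MTT assay, with a stated time of 72 h (on this read-out higher numbers stand for weaker inhibition of growth and lower numbers for stronger inhibition of growth), compound 2 (`CC(C)=CCC/C(C)=C/C(=O)NC(=N)NC(=O)C=C(C)C`) gives 31500 nM and compound 3 (`CC(C)=CCC/C(C)=C/C(=O)NC(=N)NC(=O)/C=C(\C)CCC=C(C)C`) gives 32700 nM. These two stand together, with a 1.0-fold higher number from compound 2 to compound 3 (0.02 log units; within the scatter). Compound 1 (`CC(C)=CC(=O)NC(=N)N`) gives > 100000 nM, which is a limit of the assay and not a number. Compound 2 therefore has one numerical neighbour, compound 3, and one limit value beside it.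

Compound 4 (`CC(C)=CCC/C(C)=C/C(=O)NC(=N)N`) has not yet been measured. Its difference from compound 2 is hydrogen in place of (2-methylprop-1-en-1-yl)carbonyl on an amine nitrogen.

Among the compounds with values here, no measured step removes this group. Within the data shown here, the one measured step, a 1.0-fold higher number from compound 2 to compound 3 (0.02 log units; within the scatter), alters the same group by adding 3-methylbut-2-en-1-yl but does not take it away, so it gives only weak guidance on size. The direction rests on compound 1, whose > 100000 nM is a limit. A modest move towards weaker inhibition of growth is therefore expected in this assay, and a reading that reaches the limit of > 100000 nM in this assay, at which 1 of the 3 values shown sits, is also expected to be possible.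

The estimated change is a 1.9-fold higher number from compound 2 to compound 4 (0.28 log units; within the scatter). For compound 4 the expected value is 60000 nM, with an estimated range from 25000 nM to 100000 nM.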

Compound 4, concentration for 50% growth inhibition: 39400 nM
For compound 4 the middle estimate is 1.5-fold (0.18 log units) above the measured one; the measured number falls inside the stated range.
By their numbers in this assay, from the lowest: compounds 2, 3 and 4 (each within the scatter of the next). At a limit, above all of these: compound 1.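

Hydrogen in place of (2-methylprop-1-en-1-yl)carbonyl on an amine nitrogen gives a 1.3-fold higher number from compound 2 to compound 4 (0.10 log units; within the scatter) in this assay, so this assay does not separate compounds with and without this acyl group on this core. Compound 1 gives > 100000 nM, which is a limit of the assay and not a number. Seen against that limit, 3-methylbut-2-en-1-yl in place of hydrogen on a saturated chain carbon bound to a double-bonded chain carbon gives an at least 2.5-fold lower number from compound 1 to compound 4 (0.40 log units; beyond the scatter), so this change registers on the core of compound 1 with the acyl group absent, which the earlier step on the core of compound 2 did not show, and how far the two steps really differ stays unsettled: the same change on two cores in this assay, a 1.0-fold higher number (0.02 log units; within the scatter) from compound 2 to compound 3 and an at least 2.5-fold lower number (0.40 log units; beyond the scatter) from compound 1 to compound 4; the limit leaves it open whether they differ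

The compounds shown leave open whether a longer chain in place of the 3-methylbut-2-en-1-yl part would move the number beyond the scatter of compound 4. They also leave open whether an acetyl or benzoyl group on the same amine nitrogen would stay within the scatter of compound 2 and compound 4.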